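4-methylphenyl in place of thiophen-2-yl: working notes

The source may hold more compounds than are shown below. What is called first, only, known or untested is meant among the compounds shown, and "the series" means these compounds.

Values so far from an ADME assay on L929 cells (Mus musculus) for cytotoxicity, read by resazurin assay, with a stated time of 72 h (a higher number here means a weaker inhibitor, a lower number a stronger inhibitor), each one a limit and not a number:
- Compound 1 `O=C(/C=C/c1ccc2c(c1)B(O)OC2)c1ccccn1` gives > 10 ug/mL as a limit
- Compound 2 `O=C(/C=C/c1ccc2c(c1)B(O)OC2)c1ccc(O)cc1` gives > 10 ug/mL as a limit
- Compound 3 `O=C(/C=C/c1ccc2c(c1)B(O)OC2)c1cccs1` gives > 10 ug/mL as a limit

Compound 3 is known only as a limit (> 10 ug/mL) and has no number. Compound 1, compound 2 and compound 3 all sit at the limit of > 10 ug/mL in this assay, at which 3 of the 3 values shown sit, and no order among them can be read.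

Compound 4 `Cc1ccc(C(=O)/C=C/c2ccc3c(c2)B(O)OC3)cc1` carries 4-methylphenyl in place of thiophen-2-yl on a carbonyl carbon. Three measured steps change this same place (a step that the two limits leave unreadable from compound 1 to compound 2 and a step that the two limits leave unreadable from compound 1 to compound 3 and a step that the two limits leave unreadable from compound 2 to compound 3). None of them gives a size or a direction, so they offer no support for expecting a shift beyond the scatter in this assay in either direction. The estimate therefore means an expected step that the limit leaves unreadable from compound 3 to compound 4 and rests on the limit for compound 3 (> 10 ug/mL) with wide margins. The estimated value for compound 4 is 15 ug/mL with an expected range from 6 ug/mL to 40 ug/mL and a report as a limit is the likeliest outcome.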

Compound 4, half-maximal inhibitory concentration: > 10 ug/mL
Compound 4 was reported as a limit; the forecaster's own chance of this, stated with the estimate: 75%; the middle value lies beyond the limit too.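

No step from compound 1, compound 2 or compound 3 to compound 4 can be read in this assay, because each value is a limit and not a number: the limit of > 10 ug/mL in this assay, at which 4 of the 4 values shown sit.

The compounds shown leave open how these four compounds rank and whether any group on the carbonyl carbon shifts the read-out at all.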